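The compounds below may be only part of what the source reports. "The series", "measured", "known", "first", "only" and "open" are said of these compounds alone.

Measured in an ADME assay on microsomes from liver (Homo sapiens) for metabolic stability, using NADPH, with a stated time of 10 min; on this read-out higher numbers stand for a more stable compound and lower numbers for a less stable compound:
Compound 1 `CCCCc1nc(=O)c(S(=O)(=O)c2ccc(-c3ccnc(NC(=O)C4CC4)c3)cc2)c(O)n1-c1c(OC)cccc1OC` gives 84%.
Compound 2 `CCCCc1nc(=O)c(S(=O)(=O)c2ccc(-c3cccnc3)cc2)c(O)n1-c1c(OC)cccc1OC` gives 88%.
Compound 3 `CCCCc1nc(=O)c(S(=O)(=O)c2ccc(-n3cc(Cl)ccc3=O)cc2)c(O)n1-c1c(OC)cccc1OC` gives 94%.

Compound 3 gives the highest of the three numbers, yet a number 6 percentage points higher from compound 2 to compound 3 (within the scatter) and a number 10 percentage points higher from compound 1 to compound 3 (within the scatter) are both within the scatter, so the three compounds cannot be told apart on this read-out. Compound 4 `CCCCc1nc(=O)c(S(=O)(=O)c2ccccc2)c(O)n1-c1c(OC)cccc1OC` is compound 3 with a hydrogen atom in place of a group of 8 heavy atoms (5 carbon, 1 nitrogen, 1 oxygen, 1 chlorine; one six-membered aromatic ring with 1 hetero atom), on an aromatic carbon. Going by the values given here, no measured step removes this group altogether; the step that comes closest, a smaller group in place of a larger one, is a number 4 percentage points higher from compound 1 to compound 2 (within the scatter), and it too stayed within the scatter. Taking the three steps together, no change beyond the scatter is expected in this assay for compound 4: an estimated a number 6 percentage points lower from compound 3 to compound 4 (within the scatter). Compound 4 is therefore expected at about 88%, within a range of 75% to 98%.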

Compound 4, percent of the compound remaining: 89%
Compound 4: middle estimate off by 1 percentage points, on the low side, and the stated range covers the measured number.
By their numbers in this assay, from the lowest: compounds 1, 2, 4 and 3 (each within the scatter of the next).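

In this assay the steps to hydrogen are a number 5 percentage points lower from compound 3 to compound 4 (within the scatter) and a number 1 percentage points higher from compound 2 to compound 4 (within the scatter) and a number 5 percentage points higher from compound 1 to compound 4 (within the scatter) at this place on the six-membered aromatic ring of carbon only. Thus, removing each of the three groups altogether, not only exchanging one for another, leaves the number within the scatter. No available evidence explains this result.

From the compounds shown here alone, it stays open whether an amine or a carboxylic acid at this place would move the number beyond the scatter. The compounds shown also leave open whether any change elsewhere on the shared core would do so.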